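Thiophene in Place of Nitrophenyl on the Amide

This account rests on a few compounds, and the source may have more. Where it says the series, first, only, none or still open, it means among the compounds named here.

Three amides on a shared core have been measured in an assay for binding affinity to 5-hydroxytryptamine receptor 1F (Homo sapiens), read by radioligand binding; on this read-out higher numbers stand for weaker inhibition and lower numbers for stronger inhibition. Compound 1 `CCCCCCCC(=O)Nc1ccc2[nH]cc(C3CCN(C)CC3)c2n1` gives 20 nM and compound 2 `CN1CCC(c2c[nH]c3ccc(NC(=O)C4CCCCC4)nc23)CC1` gives 20 nM; between them no change at the digits printed from compound 1 to compound 2 (within the scatter). Compound 3 `CN1CCC(c2c[nH]c3ccc(NC(=O)c4ccc([N+](=O)[O-])cc4)nc23)CC1` gives 7.7 nM, the lowest of the three numbers, reached by a 2.6-fold lower number from compound 1 to compound 3 (0.41 log units; beyond the scatter) and by a 2.6-fold lower number from compound 2 to compound 3 (0.41 log units; beyond the scatter). Compound 4 `CN1CCC(c2c[nH]c3ccc(NC(=O)c4cccs4)nc23)CC1` differs from compound 3 by thiophen-2-yl in place of 4-nitrophenyl on a carbonyl carbon. Among the measured compounds shown here, no measured step exchanges one aromatic group for another; the two steps that reach compound 3 only show an aromatic amide doing modestly better than an alkyl one. The number for compound 4 in this assay is therefore expected to stay close to that of compound 3, with no more than a small step in either direction. The step of a 1.6-fold higher number from compound 3 to compound 4 (0.19 log units; within the scatter) that this expectation implies is expected to remain small. Compound 4 is estimated at 12 nM, probably between 4 nM and 40 nM.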

Compound 4, inhibition constant: 7.1 nM
Estimate against measurement, compound 4: 1.7-fold (0.23 log units) above; the range from low to high includes it.
By their numbers in this assay, from the lowest: compounds 4 and 3 (each within the scatter of the next); then compounds 1 and 2 (each within the scatter of the next).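

In this assay, among the compounds shown here, the first exchange of one aromatic group for another on this carbonyl carbon stays within the scatter (a 1.1-fold lower number from compound 3 to compound 4 (0.04 log units; within the scatter)), so a five-membered aromatic ring with sulfur reads like the six-membered 4-nitrophenyl ring. The aromatic advantage over the alkyl amides therefore does not depend on the 4-nitrophenyl group alone, as thiophen-2-yl also reads lower than cyclohexyl (a 2.8-fold lower number from compound 2 to compound 4 (0.45 log units; beyond the scatter)) and heptyl (a 2.8-fold lower number from compound 1 to compound 4 (0.45 log units; beyond the scatter)). Nothing available explains why the two aromatic groups read alike.

As far as these compounds go, whether an unsubstituted phenyl, a furan-2-yl or a pyridine ring on this carbonyl carbon would read the same remains open.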